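A Chlorophenyl Swap and the Expected Cell Toxicity

The source may report more compounds than this note shows. Statements on the series, on what has been measured and on what is new or still open speak of the compounds shown alone.

Of the compounds shown here, three built on one shared core have been tested in an ADME assay on Huh-7 cells (Homo sapiens) for cytotoxicity; on this read-out higher numbers stand for lower toxicity in this test and lower numbers for higher toxicity in this test. Compound 1 `CN1CCN(CCNCc2cn(-c3ccc(F)cc3F)nc2-c2ccc(S(=O)(=O)N(C)C)cc2)CC1` carries a 4-(dimethylsulfamoyl)phenyl group on its core. In this assay compound 1 gives > 20000 nM, which is a limit of the assay and not a measured number. Compound 2 `Cc1ccccc1-c1nn(-c2ccc(F)cc2F)cc1CN1CCC(N2CCCCC2)CC1` likewise reaches only the limit of > 20000 nM. Compound 3 `Cc1ccccc1-c1nn(-c2ccc(F)cc2F)cc1CNC1CCN(S(C)(=O)=O)CC1` also stops at the limit of > 20000 nM. Compound 1 thus stands exactly where the whole set stands, because of the limit of > 20000 nM in this assay, at which 3 of the 3 values shown sit.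

Compound 4 `CN1CCN(CCNCc2cn(-c3ccc(F)cc3F)nc2-c2ccccc2Cl)CC1` differs from compound 1 in one place: 2-chlorophenyl in place of 4-(dimethylsulfamoyl)phenyl on an aromatic carbon. Among the measured compounds shown here, no two measured compounds differ in only one place, so no measured step guides this change, and the three values give a flat picture at the limit. The expected step of a number no higher from compound 1 to compound 4 (the limit leaves the size open) is none beyond the scatter. Compound 4 is therefore estimated to give about 20000 nM, between 8000 nM and 40000 nM, and most likely again reported as a limit.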

Compound 4, half-maximal cytotoxic concentration: > 20000 nM
Compound 4 was reported as a limit; the forecaster's own chance of this, stated with the estimate: 80%; the middle value sits exactly at the limit.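

Among the compounds shown here, compound 1 and compound 4 both stop at a limit in this assay, so no step between them can be read. The compounds shown leave open whether 2-chlorophenyl in place of 4-(dimethylsulfamoyl)phenyl changes this read-out, since none of them gives an actual number.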